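A few compounds are considered here, and "the series" means these few. Any claim that something is new, unique, unknown or untested is made for them only; others in the source may bear on it.

Measured compounds:
compound 1 `CC(C)(C)c1ccc(NC(=O)N2CCN(c3ncccc3C(F)(F)F)CC2)cc1` — 11.3 nM
compound 2 `CC(C)(C)c1ccc(NC(=S)N2CCN(c3ncccc3C(F)(F)F)CC2)cc1` — 246 nM
compound 3 `CC(C)c1ccc(NC(=O)N2CCN(c3ncccc3[N+](=O)[O-])CC2)cc1` — 190 nM

All three numbers come from a functional assay on HEK293 cells for antagonist activity at transient receptor potential cation channel subfamily V member 1 (Rattus norvegicus); on this read-out lower numbers stand for stronger inhibition and higher numbers for weaker inhibition. Compound 3 gives 190 nM, the second highest of the three numbers. Compound 2 gives 246 nM, which lies within the usual scatter of the number of compound 3, so no order between the two is claimed. Compound 1 gives 11.3 nM, far below compound 3 and well beyond the scatter; compound 1 carries trifluoromethyl rather than nitro and tert-butyl rather than isopropyl, two differences at once, so no single step can be read from it.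

Compound 4 `CC(C)c1ccc(NC(=O)N2CCN(c3ncccc3C(F)F)CC2)cc1` has not yet been measured in this assay. It differs from compound 3 in one place: difluoromethyl in place of nitro on an aromatic carbon. Among the compounds with values here, no measured pair shows this exact change. Within the data shown here, the only anchor is compound 1, whose low number in this assay comes with trifluoromethyl in the shared core. On that basis a step toward a lower number is expected from compound 3 to compound 4, of modest size, a 3.2-fold lower number from compound 3 to compound 4 (0.50 log units; beyond the scatter), with wide uncertainty. Compound 4 is estimated at 60 nM, within a range of 15 nM to 250 nM.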

Compound 4, half-maximal inhibitory concentration: 27.7 nM
Beside the measured number, compound 4's estimate is 2.2-fold (0.34 log units) above it; the range from low to high includes it.
By their numbers in this assay, from the lowest: compound 1; then compound 4; then compounds 3 and 2 (each within the scatter of the next).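

In this assay, the position ortho to a large group and two atoms from the ring nitrogen responds clearly to this exchange: difluoromethyl in place of nitro gives a 6.9-fold lower number from compound 3 to compound 4 (0.84 log units; beyond the scatter). Within the data shown here, this is the first single-place step, as compound 1 and compound 3 differ in two places at once and could not isolate the contribution of this position. The nitro group's hydrogen-bond acceptors, as counted for this change, are thus not required for a low number here, although nothing available explains the size of the step.

Open, from the compounds shown here alone, is how a nitrile, an amine or a methoxy group at this position would compare with difluoromethyl. The separate contributions of isopropyl and tert-butyl on the shared core also remain unresolved.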